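Swapping a benzyloxy for a phenyl on a shared core

The source may report more compounds than this note shows. Statements on the series, on what has been measured and on what is new or still open speak of the compounds shown alone.

Of the compounds shown here, two sharing one core have been tested for their effect on liver-derived cells. Compound 1 `O=c1cc(-c2ccccc2O)oc2cc(OCCCCCCCCN3CCCC3)ccc12` carries a hydroxyl-bearing ring on the core; in an ADME assay on HepG2 cells (Homo sapiens) for cytotoxicity, read by MTT assay, with a stated time of 48 h, tested at 10 uM (a higher number here means a stronger effect of the compound at the concentration tested, a lower number a weaker effect), compound 1 gives 60.6%. Compound 2 `O=c1cc(-c2ccc(OCc3ccccc3)cc2)oc2cc(OCCCCCCCCN3CCCC3)ccc12` instead carries a benzyloxy group on its outer ring, and in this assay compound 2 gives 54.3%. Going by the values given here, of the two numbers known, the one for compound 2 is the lower, but its gap to compound 1 falls within the usual scatter, so the two readings cannot be told apart with any confidence.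

Compound 3 `O=c1cc(-c2ccc(-c3ccccc3)cc2)oc2cc(OCCCCCCCCN3CCCC3)ccc12` is the next compound, not yet measured. Compared with compound 2, the structural change is phenyl in place of benzyloxy on an aromatic carbon. Among the compounds with values here, no step between two measured compounds matches this kind of change, so nothing in the present data points to a large movement in this assay in either direction; the expectation is a step within the scatter, not beyond it. The estimated step from compound 2 to compound 3 is a number 0.7 percentage points higher from compound 2 to compound 3 (within the scatter). Compound 3 is accordingly expected to give 55% in this assay, with a plausible range from 40% to 70%.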

Compound 3, a percentage reported as inhibition, at one concentration (the size of the read-out at that concentration, not a potency): 71.9%
Compound 3: the middle estimate sits 16.9 percentage points below what was measured, and the stated range ends below it.
By their numbers in this assay, from the lowest: compounds 2 and 1 (each within the scatter of the next); then compound 3.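

In this assay, going by these compounds alone, phenyl in place of benzyloxy on this aromatic carbon gives a number 17.6 percentage points higher from compound 2 to compound 3 (beyond the scatter), the first step here to clear the usual scatter, so the group at this position can change the reading. The comparison with the hydroxyl-bearing compound points the same way: 4-phenylphenyl in place of 2-hydroxyphenyl gives a number 11.3 percentage points higher from compound 1 to compound 3 (beyond the scatter), which places compound 3 clearly above both earlier compounds, although those two could not be told apart from each other. Nothing measured here accounts for either step, and the change from benzyloxy to phenyl removes an oxygen and two further heavy atoms in one move, so the contribution of each part stays unresolved.

The compounds shown leave open whether a benzyl group, which would keep the extra carbon but lack the oxygen, would read like compound 2 or like compound 3, and whether an amine or a carboxylic acid at the same place would hold the reading. Each compound also appears at a single concentration, so these results give no potency and do not show whether the order would hold at other concentrations.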